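Stereoisomers of one shared core in a single enzyme assay

The compounds below may be only part of what the source reports. "The series", "measured", "known", "first", "only" and "open" are said of these compounds alone.

Measured so far:
compound 1 `O=C(O)[C@H]1NC[C@H](O)[C@H](O)[C@H]1O`: 7.6%
compound 2 `O=C(O)[C@H]1NC[C@H](O)[C@@H](O)[C@H]1O`: 2.6%

In an assay on isolated protein for inhibition of cytosolic endo-beta-N-acetylglucosaminidase (Homo sapiens), tested at 1000 uM (on this read-out lower numbers stand for less inhibition and higher numbers for more inhibition at the one concentration tested (going by the name of the read-out)), compound 1 gives 7.6% and compound 2 gives 2.6%. Compound 2 stands lowest of the two numbers, with compound 1 nearest; the step of a number 5 percentage points lower from compound 1 to compound 2 (within the scatter) is within the scatter. For the measured compounds named here, the only evidence on that step is the fact that compounds 1 and 2 differ only in the configuration as drawn, so nothing more can be read from it.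

Compound 3 `O=C(O)[C@@H]1NC[C@@H](O)[C@@H](O)[C@@H]1O` is not yet measured. It differs from compound 2 by the two compounds have the same atoms and bonds and differ only in configuration as drawn: 3 of 4 stereo elements differ; a stereocentre at a saturated ring carbon is drawn S in compound 2 and R in compound 3; a stereocentre at a saturated ring carbon is drawn S in compound 2 and R in compound 3; a stereocentre at a saturated ring carbon is drawn S in compound 2 and R in compound 3. Going by the values given here, the single measured step that bears on this change is the one from compound 1 to compound 2, which was within the scatter; here three of four stereo elements change instead of one, so that step is only a loose guide. On the numbers at hand, no step beyond the scatter is expected in this assay in either direction. Compound 3 is therefore estimated at 6%, with a range from 0% to 20%, which means an expected step of a number 3.4 percentage points higher from compound 2 to compound 3 (within the scatter).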

Compound 3, a percentage reported as inhibition, at one concentration (the size of the read-out at that concentration, not a potency): 2.1%
The estimate for compound 3 lay 3.9 percentage points above the measured number; measured number inside the range.
By their numbers in this assay, from the lowest: compounds 3, 2 and 1 (each within the scatter of the next).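

In this assay, inverting three of the four stereocentres gives a number 0.5 percentage points lower from compound 2 to compound 3 (within the scatter), and inverting all four, which yields the mirror image, gives a number 5.5 percentage points lower from compound 1 to compound 3 (within the scatter). The earlier compounds shown here covered the inversion of a single stereocentre only; these steps show that even full inversion stays within the scatter, so no configuration among compounds 1, 2 and 3 stands apart in this assay. The only evidence on the full inversion is structural, and it gives no cause for any of these numbers: the fact that compounds 1 and 3 differ only in the configuration as drawn

Open, going by these compounds, is whether the configuration of the shared core matters once a read-out separates these compounds, since none of the steps here goes beyond the scatter. Also open, on these data alone, is whether a methyl ester or an amide in place of the carboxylic acid, or a longer chain on the nitrogen, would move the number beyond the scatter.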